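Swapping Chloro for Bromo on the Styryl Ring

The source may hold more compounds than are shown below. What is called first, only, known or untested is meant among the compounds shown, and "the series" means these compounds.

Measured so far:
Compound 1, `O=C(/C(=C\c1ccc(Cl)cc1)Sc1ccc(Br)cc1)c1ccc(Br)cc1`, in a functional assay on DU-145 cells (Homo sapiens) for inhibition, read by trypan blue exclusion, with a stated time of 96 h (on this read-out higher numbers stand for weaker inhibition of growth and lower numbers for stronger inhibition of growth), gives 1000 nM.
Compound 2, `O=C(/C(=C\c1ccc(Cl)cc1)SCc1ccc(Cl)cc1)c1ccc(Br)cc1`, in this assay gives 10000 nM.
Compound 3, `O=C(O)c1ccc(C(=O)/C(=C\c2ccccc2F)SCc2ccc(Br)cc2)cc1`, in this assay gives 10000 nM.

Compound 2 stands level with compound 3 at the digits shown, the two together giving the highest numbers of the three, while compound 1 sits at a lower number: a 10-fold higher number from compound 1 to compound 2 (1.00 log units; beyond the scatter).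

Compound 4, `O=C(/C(=C\c1ccc(Br)cc1)SCc1ccc(Cl)cc1)c1ccc(Br)cc1`, differs from compound 2 in one place: bromo in place of chloro on an aromatic carbon. Going by the values given here, no measured step covers a swap of this kind on this ring; the only measured step concerns a different change at the sulfur, so nothing here points to a shift in either direction. The expected step is no change at the digits printed from compound 2 to compound 4 (within the scatter), meaning no change beyond the scatter. Compound 4 is therefore estimated at 10000 nM, within a range of 4000 nM to 25000 nM.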

Compound 4, concentration for 50% growth inhibition: 1000 nM
Estimate against measurement, compound 4: 10-fold (1.00 log units) above; measured number below the stated range.
By their numbers in this assay, from the lowest: compounds 1 and 4 (each within the scatter of the next); then compounds 2 and 3 (each within the scatter of the next).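

In this assay, bromo in place of chloro gives a 10-fold lower number from compound 2 to compound 4 (1.00 log units; beyond the scatter) with the rest of the molecule unchanged. This shows that the ring position para to a large group responds to the choice of halogen, which the earlier step at the sulfur could not reveal. Nothing available here explains why exchanging one halogen for another has this result. On these data alone, what iodo or a methoxy group would give at this place remains open. So does whether the same swap has a similar result when 4-bromophenyl sits on the sulfur.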